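The compounds below may be only part of what the source reports. "The series", "measured", "known", "first", "only" and "open" are said of these compounds alone.

Measured in a functional assay on NCI-H460 cells (Homo sapiens) for cytotoxicity, read by MTT assay, with a stated time of 48 h; on this read-out lower numbers stand for stronger inhibition and higher numbers for weaker inhibition:

- compound 1 `C=C1C(=O)O[C@H]2CC3=C[C@H](C/C(C)=C/[C@@H](OC(=O)c4ccc(C(C)=O)cc4)[C@H]12)OC3=O` gives 2200 nM
- compound 2 `C=C1C(=O)O[C@H]2CC3=C[C@H](C/C(C)=C/[C@@H](OC(=O)/C=C/c4ccc(N(C)C)cc4)[C@H]12)OC3=O` gives 1300 nM
- compound 3 `C=C1C(=O)O[C@H]2CC3=C[C@H](C/C(C)=C/[C@@H](OC(=O)C45CCC(C)(C(=O)O4)C5(C)C)[C@H]12)OC3=O` gives 2000 nM

These three compounds share one core and differ only in the group on a carbonyl carbon. Compound 3, at 2000 nM, cannot be told apart from the other two, since the steps are a 1.1-fold lower number from compound 1 to compound 3 (0.04 log units; within the scatter) and a 1.5-fold higher number from compound 2 to compound 3 (0.19 log units; within the scatter). The next compound, compound 4 `C=C1C(=O)O[C@H]2CC3=C[C@H](C/C(C)=C/[C@@H](OC(=O)c4ccncc4)[C@H]12)OC3=O`, changes that same group: a group of 6 heavy atoms (5 carbon, 1 nitrogen; one six-membered aromatic ring with 1 hetero atom) in place of a group of 11 heavy atoms (9 carbon, 2 oxygen; one five-membered non-aromatic ring of carbon only, one five-membered non-aromatic ring with 1 hetero atom), on a carbonyl carbon.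

All three measured steps bear on this change. Each of them swaps this group. The third is a 1.7-fold lower number from compound 1 to compound 2 (0.23 log units; within the scatter), so none of the three goes beyond the scatter, even though the groups differ widely. Going by the values given here, none of the measured compounds carries a six-membered aromatic ring with 1 hetero atom, so this remains an extrapolation. In this assay the expected result is no change at the digits printed from compound 3 to compound 4 (within the scatter), which means no expected shift beyond the scatter in either direction. The estimated value for compound 4 is 2000 nM, with an expected range from 900 nM to 4500 nM.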

Compound 4, half-maximal inhibitory concentration: 5600 nM
Compound 4: the middle estimate sits 2.8-fold (0.45 log units) below what was measured, and the stated range ends below it.
By their numbers in this assay, from the lowest: compounds 2, 3 and 1 (each within the scatter of the next); then compound 4.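

Going by these compounds alone, until this result, the group on this carbonyl carbon could vary widely with no shift beyond the scatter in this assay. Pyridin-4-yl is the first group to bring such a shift, and it does so against all three earlier compounds (a 2.8-fold higher number from compound 3 to compound 4 (0.45 log units; beyond the scatter); a 4.3-fold higher number from compound 2 to compound 4 (0.63 log units; beyond the scatter); a 2.5-fold higher number from compound 1 to compound 4 (0.41 log units; beyond the scatter)), so this position is not indifferent to what it carries, although each step is modest and points towards weaker inhibition. Nothing at hand explains why this group behaves differently from the other three.

The compounds shown leave open whether the ring nitrogen of pyridin-4-yl matters, or simply the absence of any further group on the ring. An unsubstituted phenyl group and a pyridin-3-yl group on the same carbonyl carbon would help to separate these two readings.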